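Enlarging the Amide Substituent on a Melanin-Concentrating Hormone Antagonist Core

A few compounds are considered here, and "the series" means these few. Any claim that something is new, unique, unknown or untested is made for them only; others in the source may bear on it.

Compound 1 `CN1CCN(CCCN(C(=O)Nc2ccc(F)c(Cl)c2)C2CCc3ccc(S(C)(=O)=O)cc3C2)CC1`: 1300 nM in an assay on CHO cells for binding affinity to melanin-concentrating hormone receptor 1 (Homo sapiens); a higher number here means a weaker inhibitor, a lower number a stronger inhibitor
Compound 2 `CC(=O)Nc1ccc2c(c1)CC(N(CCCN1CCN(C)CC1)C(=O)Nc1ccc(F)c(Cl)c1)CC2`: 6 nM in this assay

Compound 2 gives the lowest number of the two measured, with compound 1 as its nearest neighbour, separated by a 220-fold lower number from compound 1 to compound 2 (2.34 log units; beyond the scatter). Compound 3 `CC(C)C(=O)Nc1ccc2c(c1)CC(N(CCCN1CCN(C)CC1)C(=O)Nc1ccc(F)c(Cl)c1)CC2` differs from compound 2 by isopropyl in place of methyl on a carbonyl carbon. Going by the values given here, no measured step alters this group in this way; the only step known, a 220-fold lower number from compound 1 to compound 2 (2.34 log units; beyond the scatter), exchanged the whole acetamido group and shows that this part of the molecule matters. For compound 3 a step of a 1.7-fold higher number from compound 2 to compound 3 (0.22 log units; within the scatter) is expected, within the scatter. Compound 3 is therefore estimated at 10 nM (range 3 nM to 40 nM).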

Compound 3, inhibition constant: 61 nM
Compound 3: middle estimate off by 6.1-fold (0.79 log units), on the low side, and the stated range ends below it.
By their numbers in this assay, from the lowest: compound 2; then compound 3; then compound 1.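

In this assay, the amide is sensitive to even a small enlargement on its carbonyl carbon: isopropyl in place of methyl gives a 10-fold higher number from compound 2 to compound 3 (1.01 log units; beyond the scatter). The larger amide still keeps part of the gain over methylsulfonyl on the aromatic carbon, with a 21-fold lower number from compound 1 to compound 3 (1.33 log units; beyond the scatter). No measurement shown here explains the loss seen with isopropyl. Open is whether the number climbs with each added carbon, since only methyl and isopropyl are shown on this carbonyl carbon. Ethyl, tert-butyl or an amine there would show whether the trend continues or whether the methyl is a special case.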